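This account rests on a few compounds, and the source may have more. Where it says the series, first, only, none or still open, it means among the compounds named here.

In an ADME assay on BJ cells (Homo sapiens) for cytotoxicity, with a stated time of 72 h (on this read-out lower numbers stand for an effect already at smaller amounts and higher numbers for an effect only at larger amounts of compound), compound 1 `C=C[C@@](C)(/C=C/c1ccc(O)cc1)CC/C=C/C(=O)OCC` gives only a limit of the assay, > 36600 nM. Compound 2 `C=C[C@@](C)(/C=C/c1ccc(O)cc1)CC/C=C/C#N` likewise reaches only a limit in this assay, > 36600 nM. Compound 3 `COc1ccc(/C=C/[C@@](C)(/C=C/c2ccc(O)c(/C=C/C#N)c2)CCC=C(C)C)cc1` is also given only as a limit, > 23700 nM. Compound 4 `CCOC(=O)/C=C/c1cc(/C=C/[C@](C)(/C=C/c2ccc(OC)cc2)CCC=C(C)C)ccc1O` has not yet been measured in this assay.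

From compound 2 to compound 1 the change is ethoxycarbonyl in place of cyano on a double-bonded chain carbon bound to a double-bonded chain carbon, and it made a step that the two limits leave unreadable from compound 2 to compound 1. Compound 4 carries the same change against compound 3, (ethoxycarbonyl in place of cyano on a double-bonded chain carbon bound to a double-bonded chain carbon), with the place worded identically. How the core of compound 3 differs from the core of compound 2 is not broken down here.

Because both ends of the earlier step sit at the limit of > 36600 nM in this assay, at which 2 of the 3 values shown sit, its size cannot be read, and compound 3 itself sits at the limit of > 23700 nM in this assay, at which 1 of the 3 values shown sits. For this change the expected step is a step that the limit leaves unreadable from compound 3 to compound 4, set beside the earlier step that the two limits leave unreadable from compound 2 to compound 1, resting on nothing more than the limits. Because compound 3 sits at the limit of > 23700 nM in this assay, at which 1 of the 3 values shown sits, compound 4 is estimated at 30000 nM, roughly between 15000 nM and 60000 nM, most likely again reported as a limit rather than a number.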

Compound 4, half-maximal effective concentration: > 36600 nM
Compound 4: only a limit was reported; the forecaster's own chance of this, stated with the estimate: 85%; middle value at least 1.2-fold (0.08 log units) away from the limit.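

Neither compound 3 nor compound 4 gives a number in this assay, only a limit each, and the step between them cannot be read. With all four compounds shown resting on limits, it remains open whether ethoxycarbonyl in place of cyano shifts the result in this assay at all, on either core.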